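Swapping the aromatic ring for a plain chain

The source may hold more compounds than are shown below. What is called first, only, known or untested is meant among the compounds shown, and "the series" means these compounds.

Compound 1: `O=C(O)Cn1c(SCCOc2ccc3ccccc3c2)nc2ccccc21`, 2500 nM
Compound 2: `O=C(O)Cn1c(SCCc2ccccc2)nc2ccccc21`, 881 nM

Both measured compounds share one core and differ only in the group hanging from the sulfur. In an assay on HEK293 cells for displacement of a labelled ligand from prostaglandin D2 receptor 2 (Homo sapiens) (a higher number here means a weaker inhibitor, a lower number a stronger inhibitor), compound 2 gives 881 nM, the lower of the two numbers. Compound 1 gives a higher number in this assay, and the gap between the two lies beyond the usual scatter, so compound 2 is the stronger inhibitor of the pair. No single-point comparison between them can be drawn, since the two groups differ in more than one place.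

Compound 3, `CCCCCSc1nc2ccccc2n1CC(=O)O`, is the next candidate. It differs from compound 2 in one place: propyl in place of phenyl on a saturated chain carbon, two bonds along the chain from a sulfur. The only ring outside the core is thus removed and a short saturated chain is left in its place.

Going by the values given here, nothing measured so far tells how such a ring-to-chain change plays out in this assay. The expectation is a step toward a weaker inhibitor, of moderate size, a 2.8-fold higher number from compound 2 to compound 3 (0.45 log units; beyond the scatter), though an outcome within the scatter cannot be excluded. Compound 3 is therefore estimated at 2500 nM, with a range from 800 nM to 8000 nM.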

Compound 3, half-maximal inhibitory concentration: 1240 nM
Compound 3: the middle estimate sits 2.0-fold (0.30 log units) above what was measured, within the range that was stated.
By their numbers in this assay, from the lowest: compounds 2, 3 and 1 (each within the scatter of the next, the first and the last beyond it).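

In this assay, propyl in place of phenyl on a saturated chain carbon, two bonds along the chain from a sulfur, gives a 1.4-fold higher number from compound 2 to compound 3 (0.15 log units; within the scatter), so the two groups cannot be told apart at this position. The aromatic ring of compound 2 is therefore not required to reach a number of this size, since compound 3 carries no ring outside the shared core and still gives a value within the scatter of compound 2. No measurement at hand explains why these two different groups give matching numbers.

The compounds shown leave open whether a cyclohexyl ring, a longer chain or an amine in the same place would shift the number beyond the scatter, and so whether this position accepts many groups or phenyl and propyl simply happen to match. Also open, going by these compounds, is whether the match between phenyl and propyl would survive with a shorter or longer link between the sulfur and the end group, since a single step on one chain cannot settle that.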